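Swapping chloro for bromo on two indole cores

This account rests on a few compounds, and the source may have more. Where it says the series, first, only, none or still open, it means among the compounds named here.

The measured compounds:
compound 1, `COC(=O)c1[nH]c2ccc(Cl)cc2c1C(=O)c1cc(OC)c(OC)c(OC)c1N`, 2140 nM;
compound 2, `COC(=O)c1[nH]c2ccc(Br)cc2c1C(=O)c1cc(OC)c(OC)c(OC)c1N`, 1940 nM;
compound 3, `COc1cc(Cc2c[nH]c3ccc(Cl)cc23)c(N)c(OC)c1OC`, "not active" (no number reported), with no number given.

In a functional assay on HT-29 cells (Homo sapiens) for cytotoxicity, read by sulforhodamine B assay, with a stated time of 48 h (a lower number here means a stronger inhibitor of growth, a higher number a weaker inhibitor of growth), compound 1 gives 2140 nM and compound 2 gives 1940 nM, and the change between them, (bromo in place of chloro on an aromatic carbon), makes a 1.1-fold lower number from compound 1 to compound 2 (0.04 log units; within the scatter). How the core of compound 3 differs from that of compound 1 is not broken down here; compound 3 is reported as "not active" (no number reported) in this assay with no number. Compound 4, `COc1cc(Cc2c[nH]c3ccc(Br)cc23)c(N)c(OC)c1OC`, is made from compound 3 by the same change, (bromo in place of chloro on an aromatic carbon). Since the change from compound 1 to compound 2 was within the scatter, compound 4 is expected to resemble compound 3 and remain weak in this assay. Compound 4 is estimated at 40000 nM, with a range of 10000 nM to 150000 nM, most likely reported again as not active.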

Compound 4, concentration for 50% growth inhibition: "not active" (no number reported)
The entry for compound 4 holds no number; the estimate stays without a comparison.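

In this assay, for the compounds shown here, compound 3 gives "not active" (no number reported) and compound 4 gives "not active" (no number reported), so no step between them can be read. The compounds shown leave open whether bromo and chloro differ on this core at all. No further evidence bears on this result.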